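From Fluoro to Ethyl on a Shared Core

This account rests on a few compounds, and the source may have more. Where it says the series, first, only, none or still open, it means among the compounds named here.

Of the compounds shown here, three built on one shared core have been tested in a functional assay on the whole organism (strain Sprague-Dawley) for inhibition, with Rattus norvegicus as the target; on this read-out lower numbers stand for an effect already at smaller amounts and higher numbers for an effect only at larger amounts of compound. Compound 1 `COc1cccc2cc(-c3nn[nH]n3)cnc12` gives 2.5 mg/kg. For compound 2 `FC(F)(F)c1cccc2cc(-c3nn[nH]n3)cnc12` the read-out is only a limit of the assay, < 25 mg/kg. For compound 3 `Fc1cccc2cc(-c3nn[nH]n3)cnc12` the read-out is again a limit of the assay, > 10 mg/kg. Compound 3 therefore stands at the weaker end of what is known here: the step of an at least 4.0-fold higher number from compound 1 to compound 3 (0.60 log units; beyond the scatter) shows that fluoro in place of methoxy costs a readable amount, while the steps a step that the limit leaves unreadable from compound 1 to compound 2 and a step that the limit leaves unreadable from compound 2 to compound 3 cannot be sized.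

Compound 4 `CCc1cccc2cc(-c3nn[nH]n3)cnc12` differs from compound 3 in one place: ethyl in place of fluoro on an aromatic carbon. Going by the values given here, no measured step on this core exchanges fluoro for ethyl, so the only guide is that compound 1 gives 2.5 mg/kg and that the step of an at least 4.0-fold higher number from compound 1 to compound 3 (0.60 log units; beyond the scatter) is at least modest. An ethyl group has not been tried here, and its effect is open. The estimate for compound 4 is 10 mg/kg, with a range from 3 mg/kg to 30 mg/kg. The expected step of a number no higher from compound 3 to compound 4 (the limit leaves the size open) is a modest gain carrying wide uncertainty, and a fair chance remains that compound 4 also reports only a limit.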

Compound 4, minimum effective dose: 2.5 mg/kg
For compound 4 the middle estimate is 4.0-fold (0.60 log units) above the measured one; measured number below the stated range.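

In this assay, ethyl in place of fluoro gives an at least 4.0-fold lower number from compound 3 to compound 4 (0.60 log units; beyond the scatter), which shows that the loss seen with fluoro at this aromatic carbon does not extend to every replacement for methoxy. Ethyl in place of methoxy gives no change at the digits printed from compound 1 to compound 4 (within the scatter), so at this position the read-out does not separate the two groups, even though the ethyl group is made of carbon only and methoxy is not; of the groups with a readable value here, fluoro alone stands apart. No measured property of these groups is given that could explain why fluoro parts from the other two.

The step between compound 2 and compound 4 cannot be read, and trifluoromethyl therefore cannot yet be placed against ethyl or methoxy on this read-out. Going by these compounds, it also remains open how far this position tolerates change, for instance whether a longer chain such as propyl, or an amine, would hold the level shared by compound 1 and compound 4 or would fall away as fluoro does.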